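Swapping furan-3-yl for thiophen-3-yl in compound 3

The compounds below may be only part of what the source reports. "The series", "measured", "known", "first", "only" and "open" are said of these compounds alone.

Compound 3 `CSc1ncnc2c1c(-c1ccoc1)cn2[C@@H]1O[C@H](CO)[C@@H](O)[C@H]1O` has no exact number in a functional assay on HepG2 cells (Homo sapiens) for antiproliferative activity, read by XTT assay, with a stated time of 72 h; a higher number here means a weaker inhibitor, a lower number a stronger inhibitor. There compound 3 gives > 15000 nM, which is a limit of the assay and not a number. Compound 1 `COc1ncnc2c1c(-c1cc3ccccc3o1)cn2[C@@H]1O[C@H](CO)[C@@H](O)[C@H]1O` also ends at a limit, > 20000 nM. Compound 2 `C#Cc1cn([C@@H]2O[C@H](CO)[C@@H](O)[C@H]2O)c2ncnc(OC)c12` gives a true number, 12700 nM.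

Going by the values given here, the only measured step runs an at least 1.5-fold lower number from compound 1 to compound 2 (0.19 log units; that floor lies within the scatter), with ethynyl in place of 1-benzofuran-2-yl. That step swaps other groups, and its floor lies within the scatter, so it offers only weak guidance here.

Compound 4 `CSc1ncnc2c1c(-c1ccsc1)cn2[C@@H]1O[C@H](CO)[C@@H](O)[C@H]1O` changes one group of compound 3: thiophen-3-yl in place of furan-3-yl on an aromatic carbon. The two groups match in every count, and sulfur takes the place of oxygen. Among the compounds with values here, no measured step tests this swap, so no shift beyond the scatter is expected. The expectation rests on compound 3, whose limit is > 15000 nM. The estimated change is a number no higher from compound 3 to compound 4 (the limit leaves the size open). Compound 4 is expected at 15000 nM, with an estimated range of 6000 nM to 35000 nM.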

Compound 4, half-maximal inhibitory concentration: > 15000 nM
Compound 4 gave a limit, no number; the forecaster's own chance of this, stated with the estimate: 60%; the middle value lies on the limit itself.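

Compound 3 and compound 4 both end at a limit of the assay and not at a number, so no step between them can be read: the limit of > 15000 nM in this assay, at which 2 of the 4 values shown sit.

The compounds shown leave open whether thiophen-3-yl in place of furan-3-yl changes the antiproliferative activity at all.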